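One Chlorine in Place of Two Fluorines

The source may hold more compounds than are shown below. What is called first, only, known or untested is meant among the compounds shown, and "the series" means these compounds.

Three compounds share a core carrying an amino-linked aromatic group, and differ only in that group. Compound 1 `CN1CCN(CCCOc2cccc3nc(Nc4ccc(Cl)c(C(F)(F)F)c4)ccc23)CC1` carries 4-chloro-3-(trifluoromethyl)phenyl; in a functional assay on A498 cells (Homo sapiens) for inhibition, read by sulforhodamine B assay, with a stated time of 48 h (a lower number here means a stronger inhibitor of growth, a higher number a weaker inhibitor of growth), compound 1 gives 1680 nM. Compound 3 `CN1CCN(CCCOc2cccc3nc(Nc4cc(Cl)cc(Cl)c4)ccc23)CC1` carries 3,5-dichlorophenyl, and compound 3 gives 1780 nM. Compound 2 `CN1CCN(CCCOc2cccc3nc(Nc4ccc(F)c(F)c4)ccc23)CC1` carries 3,4-difluorophenyl, and compound 2 gives 5660 nM, the highest number of the three: going from compound 1 to compound 2 the number rises a 3.4-fold higher number from compound 1 to compound 2 (0.53 log units; beyond the scatter), while going from compound 2 to compound 3 it falls a 3.2-fold lower number from compound 2 to compound 3 (0.50 log units; beyond the scatter).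

Compound 4 `CN1CCN(CCCOc2cccc3nc(Nc4cccc(Cl)c4)ccc23)CC1` is reached from compound 2 by the change (3-chlorophenyl in place of 3,4-difluorophenyl on a nitrogen on an aromatic ring). This keeps an amino-linked aromatic ring carrying chlorine, as in compound 3, but with a single chlorine rather than two. Within the data shown here, the only step that bears directly on it is the move from compound 2 to compound 3, which gave a modest gain; the single chlorine of compound 4 is untested, so a gain of similar or smaller size is the plain expectation. Compound 4 is therefore expected to give about 2600 nM in this assay, within a range from 1200 nM to 5600 nM. This estimate means an expected step of a 2.2-fold lower number from compound 2 to compound 4 (0.34 log units; beyond the scatter).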

Compound 4, concentration for 50% growth inhibition: 1880 nM
Compound 4: the middle estimate sits 1.4-fold (0.14 log units) above what was measured; the measured number falls inside the stated range.
By their numbers in this assay, from the lowest: compounds 1, 3 and 4 (each within the scatter of the next); then compound 2.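

In this assay, the 3-chlorophenyl group in place of 3,4-difluorophenyl gives a 3.0-fold lower number from compound 2 to compound 4 (0.48 log units; beyond the scatter), so a single chlorine on the amino-linked ring is enough to produce a change beyond the scatter, and the two chlorines of compound 3 are not required for it. Removing one chlorine, with hydrogen in place of chloro on an aromatic carbon, gives a 1.1-fold higher number from compound 3 to compound 4 (0.02 log units; within the scatter), and exchanging the whole group gives a 1.1-fold higher number from compound 1 to compound 4 (0.05 log units; within the scatter); both steps lie within the scatter, so this assay cannot tell the 3-chlorophenyl, 3,5-dichlorophenyl and 4-chloro-3-(trifluoromethyl)phenyl groups apart, and only compound 2 stands apart from the rest. Nothing measured here explains why the 3,4-difluorophenyl group gives the outlying number.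

The compounds shown leave open whether a plain phenyl ring, with no chlorine at all, would stay level with compound 4, and whether a phenyl ring with one fluorine would sit with compound 2 or with compound 4. They also leave open whether a methoxy group or a nitrile in place of the chlorine of compound 4 would hold the number.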